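Compound 4 and the Methyl on the Aromatic Nitrogen

The source may hold more compounds than are shown below. What is called first, only, known or untested is meant among the compounds shown, and "the series" means these compounds.

- Compound 1 `COc1ccc2c(c1)c(OC(C)C)c(C(N)=O)[s+]2[O-]` measured 4000 nM so far
- Compound 2 `COc1ccc2oc(C(N)=O)c(OC(C)C)c2c1` measured 5000 nM so far
- Compound 3 `COc1ccc2[nH]c(C(N)=O)c(OC(C)C)c2c1` measured 2500 nM so far

All three values come from a functional assay on HUVEC cells (Homo sapiens) for inhibition (on this read-out higher numbers stand for weaker inhibition and lower numbers for stronger inhibition), and lie within the usual scatter of one another. Compound 3 therefore stands level with compound 1 and compound 2 on these numbers, and the differences among them cannot be read as real.

Compound 4 `COc1ccc2c(c1)c(OC(C)C)c(C(N)=O)n2C` has not yet been measured. It differs from compound 3 by methyl in place of hydrogen on an aromatic nitrogen as methyl in place of hydrogen on an aromatic nitrogen, next to the ring atom that bears a carbamoyl group.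

Going by the values given here, no measured pair shows the effect of this exact change, so the only anchor is compound 3 at 2500 nM in the same test. The expected outcome in this assay is no shift beyond the scatter, with the estimated step of a 1.2-fold higher number from compound 3 to compound 4 (0.08 log units; within the scatter) as the size of that expectation. For compound 4 the estimated value is 3000 nM with an expected range from 1000 nM to 9000 nM in this read-out.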

Compound 4, half-maximal inhibitory concentration: 3700 nM
Beside the measured number, compound 4's estimate is 1.2-fold (0.09 log units) below it; measured number inside the range.
By their numbers in this assay, from the lowest: compounds 3, 4, 1 and 2 (each within the scatter of the next).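

In this assay, going by these compounds alone, methyl in place of hydrogen on the aromatic nitrogen gives a 1.5-fold higher number from compound 3 to compound 4 (0.17 log units; within the scatter) and so stays within the scatter, which makes this the first comparison here of two compounds differing in one place. At this position, the hydrogen on the aromatic nitrogen can therefore be replaced by methyl with no change that this test can resolve, so the hydrogen is not shown to be required for the inhibition read here. No available measurement accounts for the size of this step.

From the compounds shown here alone, what a larger group on this nitrogen would do, such as an ethyl group, a longer chain or a chain ending in an amine, remains open. Also open, going by these compounds, is how a carboxylic acid in place of the carbamoyl group would read in this assay on the core of compound 4.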